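The source may hold more compounds than are shown below. What is called first, only, known or untested is meant among the compounds shown, and "the series" means these compounds.

Two analogues of a shared core have been measured in an assay on isolated protein for agonist activity at Gonadotropin-releasing hormone receptor (Homo sapiens); a lower number here means a stronger inhibitor, a higher number a weaker inhibitor. Compound 1 `CCCC(=O)Nc1ccc(-c2cn3c(=O)c(C(=O)OCC)cn(Cc4ccccc4F)c3n2)cc1` carries no substituent at the ring carbon in question and gives 30000 nM in this assay. Compound 2 `CCCC(=O)Nc1ccc(-c2nc3n(Cc4ccccc4F)cc(C(=O)OC(CC)CC)c(=O)n3c2CN(C)Cc2ccco2)cc1` bears a (((furan-2-yl)methyl)(methyl)amino)methyl group at that position and gives 29 nM in this assay, the lowest of the two numbers, with compound 1 standing a long way above it, well beyond the scatter.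

Compound 3 `CCCC(=O)Nc1ccc(-c2nc3n(Cc4ccccc4F)cc(C(=O)OC(CC)CC)c(=O)n3c2N2CCC3C=CC=CC3C2)cc1` is the one still to be measured. It differs from compound 2 in a single place: a group of 10 heavy atoms (9 carbon, 1 nitrogen; one six-membered non-aromatic ring of carbon only, one six-membered non-aromatic ring with 1 hetero atom) in place of a group of 9 heavy atoms (7 carbon, 1 nitrogen, 1 oxygen; one five-membered aromatic ring with 1 hetero atom), on an aromatic carbon. Within the data shown here, no pair differing only in this way has been measured, so the size of this step can only be anticipated. Because compound 2 already reaches 29 nM, and the change keeps a nitrogen-bearing substituent on the same aromatic carbon, the step from compound 2 to compound 3 is expected to be modest and, if anything, toward a higher number, a 3.4-fold higher number from compound 2 to compound 3 (0.54 log units; beyond the scatter). Compound 3 is therefore estimated at 100 nM in this assay, within a range from 20 nM to 600 nM.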

Compound 3, inhibition constant: 290 nM
Compound 3: the middle estimate sits 2.9-fold (0.46 log units) below what was measured; the measured number falls inside the stated range.
By their numbers in this assay, from the lowest: compound 2; then compound 3; then compound 1.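

Exchanging the (((furan-2-yl)methyl)(methyl)amino)methyl group for a group with two six-membered non-aromatic rings, on the same aromatic carbon, gives a 10-fold higher number from compound 2 to compound 3 (1.00 log units; beyond the scatter) in this assay. The result shows that this position does not respond merely to the presence of a nitrogen-bearing group: these two groups are close in heavy-atom count and each holds one nitrogen, yet they are not interchangeable here. No measurement available here bears on why the step has this size.

This single step changes several features at once, since the five-membered aromatic ring leaves, the nitrogen becomes a ring member and two double bonds outside aromatic rings enter, so the compounds shown do not tell which of these features accounts for the change. As far as these compounds go, it also remains open where a simpler group at this position, such as a (dimethylamino)methyl group or a piperidine ring, would fall relative to compound 2 and compound 3.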